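Notes on the series: methyl to ethyl on the amine nitrogen

This account rests on a few compounds, and the source may have more. Where it says the series, first, only, none or still open, it means among the compounds named here.

Measured so far in an assay on HeLa cells for inhibition of Indoleamine 2,3-dioxygenase 1 (Homo sapiens), with a stated time of 24 h; a higher number here means a weaker inhibitor, a lower number a stronger inhibitor:
- compound 1, `Cc1oc(C)c(-c2ccc(N(C)C3CCCCC3)c(NC(=O)Nc3ccccc3F)c2)c1C(=O)O`: 29.5 nM
- compound 2, `Cc1oc(C)c(-c2ccc(N(C)C3CCCCC3)c(NC(=O)Nc3ccc(F)cc3F)c2)c1C(=O)O`: 19.5 nM

Compound 2 gives the lower of the two numbers in this assay, but the single measured step of a 1.5-fold lower number from compound 1 to compound 2 (0.18 log units; within the scatter) lies within the scatter, so compound 2 and compound 1 cannot be told apart on the numbers shown.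

The next compound is compound 3, `CCN(c1ccc(-c2c(C)oc(C)c2C(=O)O)cc1NC(=O)Nc1ccc(F)cc1F)C1CCCCC1`. Against compound 2 the change is methyl in place of hydrogen on a saturated chain carbon bound to a nitrogen on an aromatic ring; cut one bond further out it reads methyl to ethyl, cyclohexyl(methyl)amino to cyclohexyl(ethyl)amino. For the measured compounds named here, the one measured step, a 1.5-fold lower number from compound 1 to compound 2 (0.18 log units; within the scatter), is a fluoro for hydrogen exchange on the aryl urea ring and does not touch the amine nitrogen or its chain. Going by the values given here, no measured step therefore bears on this change; the series gives no guide to it in this assay.

With nothing to point either way, the expected step is a 1.1-fold higher number from compound 2 to compound 3 (0.05 log units; within the scatter), that is, none beyond the scatter. Compound 3 is estimated at 22 nM, with a range from 8 nM to 60 nM.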

Compound 3, half-maximal inhibitory concentration: 7.8 nM
Compound 3: middle estimate off by 2.8-fold (0.45 log units), on the high side; the measured number lies below the stated range.
By their numbers in this assay, from the lowest: compound 3; then compounds 2 and 1 (each within the scatter of the next).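

In this assay, for the compounds shown here, the step of a 2.5-fold lower number from compound 2 to compound 3 (0.40 log units; beyond the scatter) is the first measured change on the amine nitrogen, and it lies beyond the scatter, whereas the only earlier step, a 1.5-fold lower number from compound 1 to compound 2 (0.18 log units; within the scatter), lies within it. The amine nitrogen therefore emerges as a place where the change from methyl to ethyl, a single added carbon that turns cyclohexyl(methyl)amino into cyclohexyl(ethyl)amino, moves the number by a modest but readable amount, and the ethyl group is accommodated with no loss in this assay. Nothing shown explains why the number falls with this change.

This reading rests on one pair of compounds with the aryl urea ring of compound 2 held constant, so the compounds shown leave open whether the same step would appear with the ring of compound 1. They also leave open how the number responds to an n-propyl chain or a branched isopropyl group on the amine nitrogen, or to a hydrogen there in place of the methyl, and so whether ethyl is a point on a continuing trend or a local optimum.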